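From dimethylamino to 4-bromobenzylamino on a shared core

A few compounds are considered here, and "the series" means these few. Any claim that something is new, unique, unknown or untested is made for them only; others in the source may bear on it.

Compound 2 `COc1cc(Oc2cccc(Nc3ccccc3)c2)cc(OC)c1CN(C)C` carries a dimethylamino group on a saturated chain carbon bound to an aromatic carbon. For the measured compounds named here, in a functional assay on HCT-15 cells (Homo sapiens) for inhibition, read by MTT assay, with a stated time of 72 h (a lower number here means a stronger inhibitor, a higher number a weaker inhibitor), compound 2 gives 15600 nM, the higher of the two numbers measured so far, meaning the weaker inhibitor. Its nearest neighbour is compound 1 `COc1cc(Oc2cccc(Nc3ccccc3)c2)cc(OC)c1CNCc1ccc(Cl)cc1`, which in this assay gives 4850 nM. Going by the values given here, the only measured step, a 3.2-fold higher number from compound 1 to compound 2 (0.51 log units; beyond the scatter), shows that replacing a (4-chlorobenzyl)amino group with dimethylamino raised the number.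

Compound 3 `COc1cc(Oc2cccc(Nc3ccccc3)c2)cc(OC)c1CNCc1ccc(Br)cc1` has not been measured. It differs from compound 2 by (4-bromobenzyl)amino in place of dimethylamino on a saturated chain carbon bound to an aromatic carbon. This is the reverse of the measured step, with bromine in place of chlorine on the six-membered aromatic ring of carbon only. The step from compound 1 to compound 2 bears directly on it, and the expectation is that going back to a benzylamino group lowers the number by about the same amount. A step of a 3.5-fold lower number from compound 2 to compound 3 (0.54 log units; beyond the scatter) is therefore expected. Compound 3 is estimated to give 4500 nM in this assay, within a range from 2000 nM to 12000 nM.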

Compound 3, half-maximal inhibitory concentration: 5410 nM
Beside the measured number, compound 3's estimate is 1.2-fold (0.08 log units) below it; the range from low to high includes it.
By their numbers in this assay, from the lowest: compounds 1 and 3 (each within the scatter of the next); then compound 2.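

The lower number on leaving dimethylamino now appears with a second benzylamino group: in this assay the change gives a 2.9-fold lower number from compound 2 to compound 3 (0.46 log units; beyond the scatter), which matches the direction seen earlier with the chlorine-bearing compound. Both (4-halobenzyl)amino compounds shown therefore give lower numbers than the dimethylamino compound, and neither goes against this pattern. Exchanging the halogen gives a 1.1-fold higher number from compound 1 to compound 3 (0.05 log units; within the scatter), so chloro and bromo cannot be told apart in this assay, and nothing available explains either result.

The change from dimethylamino to (4-bromobenzyl)amino brings in a six-membered aromatic ring and a hydrogen-bond donor together, and the compounds shown do not separate these two changes. A plain benzylamino group with no halogen, or a methylamino group with no ring, would be needed to show which part of the change goes with the lower number, while a fluoro or methoxy group on the ring would test whether the indifference between chloro and bromo extends beyond these two halogens.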